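The source may report more compounds than this note shows. Statements on the series, on what has been measured and on what is new or still open speak of the compounds shown alone.

Series notes. Compound 1 `CC(C)(C)c1ccc(CNCCCNS(=O)(=O)c2cc(C(F)(F)F)cc(C(F)(F)F)c2)cc1`, compound 2 `COc1cccc(CNCCCNS(=O)(=O)c2cc(C(F)(F)F)cc(C(F)(F)F)c2)c1` and compound 3 `O=S(=O)(NCCCNCc1cccc(Cl)c1)c1cc(C(F)(F)F)cc(C(F)(F)F)c1` share one core and differ only in the group sitting on a saturated chain carbon bound to an amine nitrogen. In a functional assay on HT-29 cells (Homo sapiens) for inhibition, read by MTT assay, with a stated time of 72 h (on this read-out higher numbers stand for weaker inhibition of growth and lower numbers for stronger inhibition of growth), compound 1 gives 2000 nM, compound 2 gives 10000 nM and compound 3 gives 14000 nM; compound 3 stands highest of the three numbers, nearest to compound 2 and furthest from compound 1. The measured steps read a 5.0-fold higher number from compound 1 to compound 2 (0.70 log units; beyond the scatter), a 7.0-fold higher number from compound 1 to compound 3 (0.85 log units; beyond the scatter) and a 1.4-fold higher number from compound 2 to compound 3 (0.15 log units; within the scatter). Compound 4 `O=S(=O)(NCCCNCC1COc2ccccc2O1)c1cc(C(F)(F)F)cc(C(F)(F)F)c1` has not been measured; it differs from compound 3 by 2,3-dihydro-1,4-benzodioxin-2-yl in place of 3-chlorophenyl on a saturated chain carbon bound to an amine nitrogen. All three measured steps bear on this change, each being a swap of the group at that same place: two were modest and one fell within the scatter. The expectation for compound 4 in this assay is therefore a step of a 1.4-fold lower number from compound 3 to compound 4 (0.15 log units; within the scatter), with no firm ground for a move beyond the scatter in either direction. Compound 4 is estimated at 10000 nM, with a range from 3000 nM to 30000 nM.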

Compound 4, concentration for 50% growth inhibition: 2200 nM
For compound 4 the middle estimate is 4.5-fold (0.66 log units) above the measured one; the whole stated range lies above it.
By their numbers in this assay, from the lowest: compounds 1 and 4 (each within the scatter of the next); then compounds 2 and 3 (each within the scatter of the next).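

In this assay the change to 2,3-dihydro-1,4-benzodioxin-2-yl gives a 6.4-fold lower number from compound 3 to compound 4 (0.80 log units; beyond the scatter) and a 4.5-fold lower number from compound 2 to compound 4 (0.66 log units; beyond the scatter), so a low number at this place no longer rests on 4-(tert-butyl)phenyl alone. The step of a 1.1-fold higher number from compound 1 to compound 4 (0.04 log units; within the scatter) is within the scatter, which shows that a group with a non-aromatic ring carrying 2 hetero atoms can match 4-(tert-butyl)phenyl here, while 3-chlorophenyl and 3-methoxyphenyl stay apart from both. No measurement at hand accounts for these steps.

Open, on these data alone, is whether the two ring oxygen atoms of compound 4 matter, which the same ring system with a methylene in place of each oxygen would test. Also open, as far as these compounds go, is how a longer chain linking the two nitrogens would read with this group in place.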